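Trimming a hydroxylated side chain down to ethyl

The source may report more compounds than this note shows. Statements on the series, on what has been measured and on what is new or still open speak of the compounds shown alone.

The compounds share one core, a methoxy-substituted pyridine carrying a ketone linked to a cyclopropane carboxylic acid, and differ in the substituents on the aromatic nitrogen. Compound 1 `COc1cc(N(CC2CC2)c2ccc(Cl)c3ccccc23)cnc1C(=O)[C@H]1C[C@@H]1C(=O)O` bears a cyclopropylmethyl group and a chloronaphthyl ring; in an ADME assay on cells (Hepatocyte, Homo sapiens) for metabolic stability, read by LC-MS, with a stated time of 60 min, tested at 1 uM (a lower number here means slower removal, a higher number faster removal of the compound), compound 1 gives 5 uL/min. Compound 2 `COc1cc(N(CC2CC2)c2cccc(C(F)(F)F)c2)cnc1C(=O)[C@H]1C[C@@H]1C(=O)O` keeps the cyclopropylmethyl group but carries a trifluoromethyl-substituted phenyl ring, and in this assay compound 2 gives 2.3 uL/min. On these data alone, compound 3 `COc1cc(N(CC(C)(C)O)c2cccc(C(F)(F)F)c2)cnc1C(=O)[C@H]1C[C@@H]1C(=O)O` pairs the same trifluoromethylphenyl ring with a 2-hydroxy-2-methylpropyl chain; in this assay compound 3 is reported as "not determined" (no result reported), so its standing among the measured values is unknown.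

Compound 4 `CCN(c1cccc(C(F)(F)F)c1)c1cnc(C(=O)[C@H]2C[C@@H]2C(=O)O)c(OC)c1` arises from compound 3 by a single change: methyl in place of 1-hydroxy-1-methylethyl on a saturated chain carbon bound to a nitrogen on an aromatic ring. Cut one bond further out, the 2-hydroxy-2-methylpropyl chain becomes ethyl. Among the measured compounds shown here, no measured pair shows this exact step, so its size cannot be read from the data. The closest guide is compound 2, whose value of 2.3 uL/min belongs to a molecule with the same aromatic ring and a short hydrocarbon chain on the nitrogen. Compound 4 is therefore expected to fall near that figure, at roughly 3 uL/min, with the estimate spanning 1 uL/min to 9 uL/min.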

Compound 4, intrinsic clearance in a liver preparation (reported as CLH), per the amount of preparation that the assay uses: 3.1 uL/min
Beside the measured number, compound 4's estimate is 1.0-fold (0.01 log units) below it, and the stated range covers the measured number.
By their numbers in this assay, from the lowest: compounds 2, 4 and 1 (each within the scatter of the next, the first and the last beyond it).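

Among the compounds shown here, compound 4 gives the first measured pair at this position: with the trifluoromethyl-substituted phenyl ring kept, methyl in place of cyclopropyl on a saturated chain carbon bound to a nitrogen on an aromatic ring gives a 1.3-fold higher number from compound 2 to compound 4 (0.13 log units; within the scatter) in this assay. Ethyl and cyclopropylmethyl on the nitrogen therefore cannot be told apart in this assay, so the small ring in that chain can be removed without a difference larger than repeated measurements would show. Nothing measured here explains why the two compounds read alike.

Compound 3 has no reported result, so the effect of the 2-hydroxy-2-methylpropyl chain in this assay remains unknown, and the compounds shown cannot say whether its hydroxyl group matters at this position. Also open, on these data alone, is whether a longer chain, such as propyl, or a chain carrying an amine in place of the ethyl would stay within the same narrow range, and whether ethyl would behave the same way alongside the chloronaphthyl ring of compound 1.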